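The compounds below may be only part of what the source reports. "The series", "measured", "known", "first", "only" and "open" are said of these compounds alone.

Measured compounds:
- compound 1 `Nc1scc(-c2ccc(F)cc2)c1C(=O)c1ccc(Cl)cc1` gives 61%
- compound 2 `Nc1scc(-c2cccc(Cl)c2)c1C(=O)c1ccc(Cl)cc1` gives 75%

In a functional assay on CHO cells for agonist activity at adenosine receptor A1 (Homo sapiens), read by fluorescence and ERK phosphorylation, with stated times of 30 min and 1.5 h, tested at 10 uM (on this read-out higher numbers stand for a stronger effect at the one concentration tested and lower numbers for a weaker effect), compound 2 stands highest of the two numbers, and compound 1 sits lower. Going by the values given here, the only measured step, a number 14 percentage points higher from compound 1 to compound 2 (beyond the scatter), concerns a different part of the molecule and so does not directly speak to the change at hand. Compound 3 `Nc1scc(-c2cccc(Br)c2)c1C(=O)c1ccc(Cl)cc1` differs from compound 2 by bromo in place of chloro on an aromatic carbon. Among the compounds with values here, with no measured step bearing on this swap, the expected step of no change at the digits printed from compound 2 to compound 3 (within the scatter) is small, not beyond the scatter. Compound 3 is therefore estimated at 75%, with a range from 55% to 92%.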

Compound 3, a percentage reported as activity, at one concentration (the size of the read-out at that concentration, not a potency): 69%
Beside the measured number, compound 3's estimate is 6 percentage points above it, and the stated range covers the measured number.
By their numbers in this assay, from the lowest: compounds 1, 3 and 2 (each within the scatter of the next, the first and the last beyond it).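

In this assay, swapping one halogen for another at this position leaves the read-out effectively unchanged: bromo in place of chloro gives a number 6 percentage points lower from compound 2 to compound 3 (within the scatter). The clear difference between 3-chlorophenyl and 4-fluorophenyl does not carry over to 3-bromophenyl, which gives a number 8 percentage points higher from compound 1 to compound 3 (within the scatter). Nothing at hand explains either step. Going by these compounds, whether a group other than a halogen, such as an amine, a methoxy group or a carboxylic acid, would hold the effect at this place remains open. So does whether the effects of these compounds would compare in the same way at any other concentration.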